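A few compounds are considered here, and "the series" means these few. Any claim that something is new, unique, unknown or untested is made for them only; others in the source may bear on it.

Measured compounds:
compound 1 `CN(C)CCCCOc1ccccc1/C=C/c1ccccc1Cl`: 14.3%
compound 2 `CN(C)CCCCOc1ccccc1/C=C/c1cccc(Cl)c1`: 14.3%
compound 3 `CN(C)CCCCOc1ccccc1/C=C/c1ccc(Cl)cc1`: 0%

In a functional assay on the whole organism with Mus musculus as the target, in the maximal electroshock model, at a dose of 50 mg/kg by the oral route (a lower number here means less inhibition, a higher number more inhibition at the dose given (going by the name of the read-out)), compound 3 stands lowest of the three numbers, shown by the step of a number 14.3 percentage points lower from compound 1 to compound 3 (beyond the scatter) and the step of a number 14.3 percentage points lower from compound 2 to compound 3 (beyond the scatter), while compounds 1 and 2 sit within the scatter of each other, as the step of no change at the digits printed from compound 1 to compound 2 (within the scatter) shows. Compound 4 `COc1ccccc1/C=C/c1ccccc1OCCCCN(C)C` differs from compound 3 in one place: 2-methoxyphenyl in place of 4-chlorophenyl on a double-bonded chain carbon bound to a double-bonded chain carbon. Among the measured compounds shown here, no measured step exchanges chlorine for methoxy; only the two modest steps ending at compound 3 bear on it, both showing that a change of the ring substituent moves this assay by a modest amount. A modest rise is therefore expected, a number 12 percentage points higher from compound 3 to compound 4 (beyond the scatter), with wide uncertainty. Compound 4 is estimated at 12%, within 0% to 35%.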

Compound 4, a percentage reported as inhibition, in the whole organism at one dose (the size of the read-out at that dose, not a potency): 0%
Estimate against measurement, compound 4: 12 percentage points above, and the stated range covers the measured number.
By their numbers in this assay, from the lowest: compounds 3 and 4 (each within the scatter of the next); then compounds 1 and 2 (each within the scatter of the next).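

Methoxy in place of chloro on an aromatic carbon gives a number 14.3 percentage points lower from compound 1 to compound 4 (beyond the scatter) in this assay and is the first measured exchange of these two groups, so at this place the value depends on the kind of substituent and not only on where it sits on the ring. The step of a number 14.3 percentage points lower from compound 2 to compound 4 (beyond the scatter) is of the same size, whereas no change at the digits printed from compound 3 to compound 4 (within the scatter) leaves 2-methoxyphenyl level with 4-chlorophenyl. No evidence on the reason for this is available. From the compounds shown here alone, whether a fluoro or hydroxy group on this ring would keep the higher number stays open.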